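This account rests on a few compounds, and the source may have more. Where it says the series, first, only, none or still open, it means among the compounds named here.

Measured compounds:
- Compound 1, `COc1ccc(N(C)c2nc(C)nc3c2CCC3)cc1`: 7 nM
- Compound 2, `C=CC1Cc2nc(C)nc(N(C)c3ccc(OC)cc3)c2C1`: 73.2 nM

The study reads potency in a functional assay on MDA-MB-435 cells (Homo sapiens) for inhibition, read by sulforhodamine B assay, with a stated time of 48 h; a higher number here means a weaker inhibitor, a lower number a stronger inhibitor. Within the data shown here, compound 1 gives 7 nM, the lowest of the two numbers so far; its nearest neighbour is compound 2, which gives 73.2 nM. Among the measured compounds shown here, the one step that joins them, a 10-fold higher number from compound 1 to compound 2 (1.02 log units; beyond the scatter), lies beyond the scatter and is large, and it concerns a vinyl in place of hydrogen on a saturated ring carbon.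

Compound 3, `COc1ccc(N(C)c2ncnc3c2CCC3)cc1`, has not yet been measured. It differs from compound 1 by hydrogen in place of methyl on an aromatic carbon. For the measured compounds named here, no measured step touches this place on the core; the only step available, from compound 1 to compound 2, concerns a different position, so it gives no direct guide to the size or direction here. With nothing measured at this position, a change within or slightly beyond the scatter, toward a higher number, is the expectation. Compound 3 is therefore estimated at 15 nM, with a range of 5 nM to 50 nM, which means an expected step of a 2.1-fold higher number from compound 1 to compound 3 (0.33 log units; beyond the scatter).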

Compound 3, half-maximal inhibitory concentration: 43 nM
Compound 3: the middle estimate sits 2.9-fold (0.46 log units) below what was measured; the range from low to high includes it.
By their numbers in this assay, from the lowest: compound 1; then compounds 3 and 2 (each within the scatter of the next).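

In this assay, replacing the methyl on the aromatic carbon between two ring nitrogen atoms with hydrogen gives a 6.1-fold higher number from compound 1 to compound 3 (0.79 log units; beyond the scatter), so this small group has a measurable bearing on the result, even though the step is modest. Among these compounds, the earlier pair spoke only to a saturated ring carbon; this is the first reading at this second place on the core, and at both places the change away from compound 1 raises the number, leaving compound 1 the strongest inhibitor of the three. Nothing available explains why losing the methyl has this effect.

As far as these compounds go, with only methyl and hydrogen seen at this carbon, it remains open whether an ethyl group, a longer chain, an amine or a chlorine atom there would bring the number below that of compound 1 or push it higher. From the compounds shown here alone, it is also open whether the loss of the methyl would cost the same on the vinyl-bearing core of compound 2, and how changes to the methoxy group or the nitrogen methyl of the shared core would read.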